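This account rests on a few compounds, and the source may have more. Where it says the series, first, only, none or still open, it means among the compounds named here.

Compound 3, `C[C@@H](NC(=O)c1ccc(C#Cc2cccnc2)cn1)C(C)(C)O`, gives 71.5% in a functional assay on HEK293 cells for positive allosteric modulation of metabotropic glutamate receptor 5 (Rattus norvegicus), read by fluorescence and calcium flux (on this read-out higher numbers stand for larger maximal responses and lower numbers for smaller maximal responses), and stands highest of the three numbers shown. Compound 2, `Cc1ccc(C#Cc2ccc(C(=O)N[C@H](C)C(C)(C)O)nc2)cc1`, gives 63.1%, and compound 1, `C[C@@H](NC(=O)c1ccc(C#Cc2cc(F)cc(F)c2)cn1)C(C)(C)O`, gives 61.6%. Both gaps to compound 3 lie within the scatter, so the three cannot be ranked. Compound 4, `C[C@@H](NC(=O)c1ccc(C#CC2CCCC2)cn1)C(C)(C)O`, differs from compound 3 in one place: cyclopentyl in place of pyridin-3-yl on a triple-bonded carbon. Going by the values given here, the steps that bear on this exchange on the triple-bonded carbon are a number 9.9 percentage points higher from compound 1 to compound 3 (within the scatter) and a number 8.4 percentage points higher from compound 2 to compound 3 (within the scatter), both within the scatter. A non-aromatic ring of carbon only in this place has not been measured among these compounds. Compound 4 is therefore expected to give 62%, with a range from 45% to 80%. The expected step is a number 9.5 percentage points lower from compound 3 to compound 4 (within the scatter), not beyond the scatter.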

Compound 4, largest response reached (reported as efficacy), in percent of the reference or control that the assay uses: 63.7%
Compound 4: middle estimate off by 1.7 percentage points, on the low side; measured number inside the range.
By their numbers in this assay, from the lowest: compounds 1, 2, 4 and 3 (each within the scatter of the next).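

Cyclopentyl on this triple-bonded carbon gives a number 7.8 percentage points lower from compound 3 to compound 4 (within the scatter) as well as a number 0.6 percentage points higher from compound 2 to compound 4 (within the scatter) and a number 2.1 percentage points higher from compound 1 to compound 4 (within the scatter) in this assay, so a non-aromatic ring of carbon only now stands level with the aromatic rings. These compounds therefore give no sign that an aromatic ring, or the hydrogen-bond acceptor of pyridin-3-yl, is required here for the maximal response. No measurement at hand explains these numbers.

As far as these compounds go, whether any group in this place can move the response beyond the scatter remains open. So does the outcome with an open propyl chain or a ring carrying an amine.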